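The source may hold more compounds than are shown below. What is called first, only, known or untested is meant among the compounds shown, and "the series" means these compounds.

Series notes. Compound 1 `CCCCCCc1cn(C(c2ccccc2)c2cc3cc(Br)ccc3nc2OC)nn1` and compound 2 `COc1nc2ccc(Br)cc2cc1C(c1ccccc1)n1cc(-c2ccccc2C(F)(F)F)nn1` share one core and differ only at an aromatic carbon of the five-membered ring. In an ADME assay on SK-OV-3 cells (Homo sapiens) for cytotoxicity, read by sulforhodamine B assay, with a stated time of 48 h, tested at 10 uM (on this read-out higher numbers stand for more inhibition at the one concentration tested (going by the name of the read-out) and lower numbers for less inhibition), compound 1 gives 7.17%. In this assay compound 2 gives 9.55%. The only step measured so far is a number 2.4 percentage points higher from compound 1 to compound 2 (within the scatter); compound 2 thus carries the larger of the two numbers, but the gap is within the scatter and no real separation between compound 1 and compound 2 is shown. Compound 3 `COc1nc2ccc(Br)cc2cc1C(c1ccccc1)n1cc(C2CC2)nn1` is the next member; its change from compound 2 is cyclopropyl in place of 2-(trifluoromethyl)phenyl on an aromatic carbon. Among the compounds with values here, the only step bearing on this position, a number 2.4 percentage points higher from compound 1 to compound 2 (within the scatter), moved nothing beyond the scatter, and no step exchanging an aryl group for a small carbocycle has been measured. In this assay the step expected is therefore a number 1.6 percentage points lower from compound 2 to compound 3 (within the scatter), none beyond the scatter. Compound 3 is estimated at 8%, with a range from 0% to 20%.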

Compound 3, a percentage reported as inhibition, at one concentration (the size of the read-out at that concentration, not a potency): 3.52%
Estimate against measurement, compound 3: 4.5 percentage points above; the measured number falls inside the stated range.
By their numbers in this assay, from the lowest: compounds 3, 1 and 2 (each within the scatter of the next).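

Cyclopropyl in place of 2-(trifluoromethyl)phenyl gives a number 6 percentage points lower from compound 2 to compound 3 (within the scatter), and cyclopropyl in place of hexyl gives a number 3.7 percentage points lower from compound 1 to compound 3 (within the scatter). In this assay, the position on the aromatic carbon of the five-membered ring has now held a three-membered ring, a six-membered aromatic ring and a hexyl chain, with no separation beyond the scatter among compound 1, compound 2 and compound 3. No evidence on hand bears on a cause for these numbers.

Open, on these data alone, is whether an amine or a carboxylic acid at this position would move the number beyond the scatter. Also open, as far as these compounds go, is whether exchanging the bromine on the shared core would do so.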